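The compounds below may be only part of what the source reports. "The series", "measured", "known", "first", "only" and "open" are said of these compounds alone.

Working notes on the series. The shared core is shown in compound 1 `COc1nc2ccc(CSc3ccccn3)cc2nc1OC`, which in an ADME assay on MT4 cells (Homo sapiens) for cytotoxicity, read by MTT assay, with a stated time of 96 h (a lower number here means that less compound is tolerated, a higher number that more compound is tolerated), gives 28000 nM. Compound 2 `CCOC(=O)CC[C@H](NC(=O)c1ccccc1SCc1ccc2nc(OC)c(OC)nc2c1)C(=O)OCC` gives 60000 nM in this assay. Compound 3 `CCOC(=O)c1ccc(SCc2ccc3nc(OC)c(OC)nc3c2)nc1` stands at a limit of this assay, reported as > 100000 nM, and this is a limit and not a number. Among the measured compounds shown here, the one measured step that reaches compound 3 is an at least 3.5-fold higher number from compound 1 to compound 3 (0.55 log units; beyond the scatter), a step beyond the scatter whose endpoint is set by the limit of > 100000 nM in this assay, at which 1 of the 3 values shown sits. Compound 4 `COc1nc2ccc(CSc3ccc(C(=O)O)cn3)cc2nc1OC` differs from compound 3 by hydrogen in place of ethyl on an oxygen next to a carbonyl group, read one bond further out as ethoxycarbonyl to carboxy. For the measured compounds named here, no measured step in this set removes the ethyl from such an oxygen, so the bearing of the known steps is indirect: compound 3 already sits at the limit, and compound 2, which carries ethoxycarbonyl groups elsewhere, also tolerates a good deal. The expected step is therefore none beyond the scatter, a number no higher from compound 3 to compound 4 (the limit leaves the size open). Compound 4 is expected to give about 100000 nM, with a range from 40000 nM to 300000 nM, and a fair chance that only a limit is reported again.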

Compound 4, half-maximal cytotoxic concentration: > 100000 nM
Compound 4 was reported as a limit (the forecaster's own chance of this, stated with the estimate: 65%); the middle value sits exactly at the limit.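

Compound 4 gives > 100000 nM in this assay, which is a limit and not a number. Carboxy in place of hydrogen on an aromatic carbon gives an at least 3.5-fold higher number from compound 1 to compound 4 (0.55 log units; beyond the scatter), so the number does not return towards that of compound 1 when the ethyl leaves the ethoxycarbonyl group, and this position tolerates the free carboxy as well as the ester. The step between compound 3 and compound 4 cannot be read: the limit of > 100000 nM in this assay, at which 2 of the 4 values shown sit.

On these data alone, the true positions of compound 3 and compound 4 stay open, so the ethyl ester and the carboxylic acid cannot be ordered in this assay. Also open, as far as these compounds go, is whether an amine or a longer chain on the same aromatic carbon would stay at the limit or give a readable number.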